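The source may hold more compounds than are shown below. What is called first, only, known or untested is meant among the compounds shown, and "the series" means these compounds.

Measured compounds:
compound 1, `COc1ccc(-c2cc(/C=C/C(=O)c3ccc(N)cc3)[nH]n2)cc1`, 103%
compound 2, `COc1ccc(-c2cc(/C=C/C(=O)c3ccc(N)cc3)[nH]n2)cc1OC`, 94%
compound 3, `COc1cc(C(=O)/C=C/c2cc(-c3cc(OC)c(OC)c(OC)c3)n[nH]2)cc(OC)c1OC`, 90%

In a functional assay on MDA-MB-468 cells (Homo sapiens) for cytotoxicity, read by sulforhodamine B assay, with a stated time of 48 h, tested at 0.01 uM (on this read-out higher numbers stand for a weaker effect at the one concentration tested and lower numbers for a stronger effect), compound 1 gives 103%, compound 2 gives 94%, and compound 3 gives 90%. The change from compound 2 to compound 1 is hydrogen in place of methoxy on an aromatic carbon; the step it made was a number 9 percentage points higher from compound 2 to compound 1 (within the scatter). Compound 3 and compound 2 do not share a single counted difference; the difference between the two cores is not broken down here. Compound 3 and compound 1 differ by a number beyond the scatter, with compound 3 the lower of the two.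

Compound 4, `COc1ccc(-c2cc(/C=C/C(=O)c3cc(OC)c(OC)c(OC)c3)[nH]n2)cc1OC`, is not yet measured in this assay. It differs from compound 3 by hydrogen in place of methoxy on an aromatic carbon. This is the same kind of change as that from compound 2 to compound 1, but the place is not the same: in compound 3 the aromatic carbon is also meta to a methoxy group, which is not so in compound 2.

On the basis of a number 9 percentage points higher from compound 2 to compound 1 (within the scatter), compound 4 is expected to differ from compound 3 by a number 7 percentage points higher from compound 3 to compound 4 (within the scatter), a step within the scatter. Compound 4 is thus estimated at 97%, with a range from 85% to 110%, because compound 3 gives 90% and the earlier step was small.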

Compound 4, a percentage reported as activity, at one concentration (the size of the read-out at that concentration, not a potency): 98%
Beside the measured number, compound 4's estimate is 1 percentage points below it; measured number inside the range.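

In this assay, hydrogen in place of methoxy on an aromatic carbon gives a number 8 percentage points higher from compound 3 to compound 4 (within the scatter). Set beside the earlier case, the change carries over from one core to the other with much the same size of step: the same change on two cores in this assay, a number 9 percentage points higher (within the scatter) from compound 2 to compound 1 and a number 8 percentage points higher (within the scatter) from compound 3 to compound 4, 1 percentage points apart, within the scatter of two such steps Both steps lie within the scatter, however, and the agreement therefore does not establish that the change has any real effect on this read-out; two pairs tested at a single concentration also say nothing about potency or about how the change would behave on further cores.

Still open, from the compounds shown here alone, is whether the same pattern holds when methoxy gives way to a hydroxy group, a fluorine atom or a longer chain such as ethoxy rather than to hydrogen. Also open, going by these compounds, is whether a step beyond the scatter would appear for this change at higher concentrations than the one used in this assay.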